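Methoxy position on the amide aryl ring

The source may hold more compounds than are shown below. What is called first, only, known or untested is meant among the compounds shown, and "the series" means these compounds.

Compound 2 `COc1ccc(C(=O)Nc2cc(Sc3ncn[nH]3)c(O)c3ccccc23)cc1` in a functional assay on MDA-MB-231 cells (Homo sapiens) for antiproliferative activity, read by MTT assay, with a stated time of 48 h (a lower number here means a stronger inhibitor, a higher number a weaker inhibitor), reaches only the limit of the assay, > 100000 nM. Within the data shown here, the one measured step into it comes from compound 1 `O=C(Nc1cc(Sc2ncn[nH]2)c(O)c2ccccc12)c1ccc2ccccc2c1`, which in this assay gives 45100 nM; the change an at least 2.2-fold higher number from compound 1 to compound 2 (0.34 log units; beyond the scatter) marks the 4-methoxyphenyl amide as the weaker of the two, and the size of that step is only bounded because compound 2 sits at the limit of > 100000 nM in this assay, at which 1 of the 2 values shown sits. Compound 3 `COc1cccc(C(=O)Nc2cc(Sc3ncn[nH]3)c(O)c3ccccc23)c1` is not yet measured. It differs from compound 2 by 3-methoxyphenyl in place of 4-methoxyphenyl on a carbonyl carbon, a rearrangement of the same atoms. No measured step in the series bears on moving the methoxy group around the phenyl ring; the only step shown exchanges the whole aryl group and is itself bounded by a limit. With nothing to set a direction, the step expected in this assay for compound 3 stays within the scatter, a number no higher from compound 2 to compound 3 (the limit leaves the size open), with a good chance that the assay again reports only its limit. Compound 3 is therefore estimated at 100000 nM, with a range from 40000 nM to 250000 nM.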

Compound 3, half-maximal inhibitory concentration: > 100000 nM
Compound 3 ended at the assay's limit; the forecaster's own chance of this, stated with the estimate: 60%; the middle value lies on the limit itself.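

In this assay compound 3 gives > 100000 nM, which is a limit of the assay and not a number. Measured against the naphthalen-2-yl amide, the 3-methoxyphenyl amide gives an at least 2.2-fold higher number from compound 1 to compound 3 (0.34 log units; beyond the scatter), so the loss on leaving naphthalen-2-yl on the carbonyl carbon now holds for two placements of the methoxy group rather than one. The step between compound 2 and compound 3 cannot be read, so moving the methoxy group gives no measurable change here, and the comparison rests on two limits: the limit of > 100000 nM in this assay, at which 2 of the 3 values shown sit.

As far as these compounds go, how far either methoxyphenyl amide lies past the limit, and whether the two differ at all, stays open. Also open, from the compounds shown here alone, is whether the loss goes with the methoxy group or with the change from naphthalen-2-yl to a single phenyl ring, and whether an unsubstituted phenyl, or a phenyl carrying a chlorine, an amine or a carboxylic acid, would return to a readable value.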